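Cyclopentyl for cyclohexylmethyl: a repeated ether change

The source may report more compounds than this note shows. Statements on the series, on what has been measured and on what is new or still open speak of the compounds shown alone.

Measured so far in an assay on SK-BR-3 cells for inhibition of Aromatase (Homo sapiens); on this read-out lower numbers stand for stronger inhibition and higher numbers for weaker inhibition:
compound 1, `CS(=O)(=O)Nc1ccc([N+](=O)[O-])cc1OCC1CCCCC1`, gives 1210 nM
compound 2, `CS(=O)(=O)Nc1ccc([N+](=O)[O-])cc1OC1CCCC1`, gives 870 nM
compound 3, `CN(c1ccc([N+](=O)[O-])cc1OCC1CCCCC1)S(C)(=O)=O`, gives 960 nM

Compound 2 differs from compound 1 by cyclopentyl in place of cyclohexylmethyl on an oxygen on an aromatic ring. In this assay this gave a 1.4-fold lower number from compound 1 to compound 2 (0.14 log units; within the scatter). Compound 3 differs from compound 1 by methyl in place of hydrogen on a sulfonamide nitrogen, and in this assay this gave a 1.3-fold lower number from compound 1 to compound 3 (0.10 log units; within the scatter). All three measured numbers lie within the scatter of one another, so no order among them can be claimed.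

Compound 4, `CN(c1ccc([N+](=O)[O-])cc1OC1CCCC1)S(C)(=O)=O`, has not yet been measured. It differs from compound 3 by cyclopentyl in place of cyclohexylmethyl on an oxygen on an aromatic ring. This is the same change as the one from compound 1 to compound 2, at a place described in exactly the same words, and it occurs twice among the compounds shown. The two cores, that of compound 1 and that of compound 3, differ by the change described above as methyl in place of hydrogen on a sulfonamide nitrogen.

The expectation for compound 4 rests on compound 1 and compound 2, where this change gave a 1.4-fold lower number from compound 1 to compound 2 (0.14 log units; within the scatter), a step within the scatter. In this assay the step from compound 3 to compound 4 is expected to be a 1.4-fold lower number from compound 3 to compound 4 (0.14 log units; within the scatter), of similar small size. Compound 4 is therefore estimated at 700 nM, with a likely range from 350 nM to 1400 nM.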

Compound 4, half-maximal inhibitory concentration: 440 nM
The estimate for compound 4 lay 1.6-fold (0.20 log units) above the measured number, within the range that was stated.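

In this assay, cyclopentyl in place of cyclohexylmethyl on the core of compound 3 gave a 2.2-fold lower number from compound 3 to compound 4 (0.34 log units; beyond the scatter), and methyl in place of hydrogen on the sulfonamide nitrogen, with cyclopentyl on the oxygen, gave a 2.0-fold lower number from compound 2 to compound 4 (0.30 log units; within the scatter). The ether change ran the same way on both cores and its two steps cannot be told apart in size, yet this is a single pair, only one of its steps lies beyond the scatter, and it does not show that the change gives a fixed step on every core: the same change on two cores in this assay, a 1.4-fold lower number (0.14 log units; within the scatter) from compound 1 to compound 2 and a 2.2-fold lower number (0.34 log units; beyond the scatter) from compound 3 to compound 4, 1.6-fold (0.20 log units) apart, within the scatter of two such steps The methyl change also ran the same way on both cores, but neither of its steps lies beyond the scatter, and it cannot be said to have moved the number on either core: the same change on two cores in this assay, a 1.3-fold lower number (0.10 log units; within the scatter) from compound 1 to compound 3 and a 2.0-fold lower number (0.30 log units; within the scatter) from compound 2 to compound 4, 1.6-fold (0.20 log units) apart, within the scatter of two such steps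

The compounds shown leave open whether the ether change would carry over to a core with a nitrile in place of the nitro group, or to a core with an ethyl group on the sulfonamide nitrogen. They also leave open how a cyclobutyl group or a longer chain on the oxygen would compare with cyclopentyl and cyclohexylmethyl on these two cores.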